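The source may hold more compounds than are shown below. What is called first, only, known or untested is meant among the compounds shown, and "the series" means these compounds.

Three compounds share one core and differ only in the group carried on a six-membered aromatic ring of carbon only. Compound 1 `COCc1cccc(-c2ccc3ccc(C)nc3c2)c1` carries a methoxymethyl group, and in a functional assay on CHO cells for inhibition of metabotropic glutamate receptor 5 (Rattus norvegicus), read by FLIPR and calcium flux (on this read-out higher numbers stand for weaker inhibition and lower numbers for stronger inhibition), compound 1 gives 5800 nM. Compound 2 `Cc1ccc2ccc(-c3cccc(O)c3)cc2n1` carries a hydroxy group instead, and in this assay compound 2 gives 19000 nM, which is a 3.3-fold higher number from compound 1 to compound 2 (0.52 log units; beyond the scatter). Compound 3 `Cc1ccc2ccc(-c3cccc(OC(F)(F)F)c3)cc2n1` carries a trifluoromethoxy group. For compound 3 this assay reports only a limit, > 10000 nM, and not a number; this is the limit of > 10000 nM in this assay, at which 1 of the 3 values shown sits. Compound 3 thus stands at the weak end of the three without an exact value: the step of an at least 1.7-fold higher number from compound 1 to compound 3 (0.23 log units; that floor lies within the scatter), and the step that the limit leaves unreadable from compound 2 to compound 3.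

Compound 4 `Cc1ccc2ccc(-c3cccc(C(N)=O)c3)cc2n1` is not yet measured. It differs from compound 3 in one place: carbamoyl in place of trifluoromethoxy on an aromatic carbon. For the measured compounds named here, no measured step involves a carbamoyl group, so none bears on this change directly. One guide is compound 2, which gives 19000 nM. The other guide is the limit at which compound 3 sits. Weak inhibition is therefore expected to persist. For compound 4 the expected value in this assay is 15000 nM, with a range from 4000 nM to 60000 nM. That estimate means an expected step that the limit leaves unreadable from compound 3 to compound 4, which, set against a limit, is not readable as a change in either direction.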

Compound 4, half-maximal inhibitory concentration: > 10000 nM
Compound 4 gave a limit, no number (the forecaster's own chance of this, stated with the estimate: 50%); the middle value does not contradict the limit.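

Compound 4 places a carbamoyl group, with 1 hydrogen-bond donor, on the aromatic carbon meta to a large group, where compound 3 carries trifluoromethoxy, with 0 hydrogen-bond donors, yet in this assay compound 4 too gives a limit and not a number: the limit of > 10000 nM in this assay, at which 2 of the 4 values shown sit.

So exchanging these two quite different groups at this position yields no measurable gain in inhibition, although the size of any difference stays hidden, and the steps to compound 4 from compound 2 and from compound 3 cannot be read. For the compounds shown here, the one readable comparison is an at least 1.7-fold higher number from compound 1 to compound 4 (0.23 log units; that floor lies within the scatter), so these data do not establish that compound 4 inhibits less strongly than compound 1.

Going by these compounds, the exact values of compound 3 and compound 4 remain open, and so does the question of whether any group at this position can give much stronger inhibition than the methoxymethyl group of compound 1. An aminomethyl group, a carboxylic acid or a longer chain such as ethoxymethyl on this aromatic carbon would extend the comparison beyond the groups shown here.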